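Ethyl on the side-chain amine nitrogen: working notes

This account rests on a few compounds, and the source may have more. Where it says the series, first, only, none or still open, it means among the compounds named here.

- compound 1 `CC(C)=CCc1cc(C(=O)Nc2cc3ccc(OCC4CCN(C)C4)c(C)c3oc2=O)ccc1O`, 920 nM
- compound 2 `CCNCCCOc1ccc2cc(NC(=O)c3ccc(O)c(CC=C(C)C)c3)c(=O)oc2c1C`, 720 nM

Among the measured compounds shown here, in a functional assay on SK-BR-3 cells (Homo sapiens) for antiproliferative activity (on this read-out lower numbers stand for stronger inhibition and higher numbers for weaker inhibition), compound 2 gives 720 nM, within the scatter of compound 1, the only other measured compound. Compound 3 `CCN(CC)CCCOc1ccc2cc(NC(=O)c3ccc(O)c(CC=C(C)C)c3)c(=O)oc2c1C` differs from compound 2 by ethyl in place of hydrogen on an amine nitrogen, which is ethyl in place of hydrogen on an amine nitrogen. For the measured compounds named here, one measured step bears on this, a 1.3-fold lower number from compound 1 to compound 2 (0.11 log units; within the scatter), where a different amine-bearing group left this assay within the scatter. Going by the values given here, no measured step isolates this ethyl change, so no shift beyond the scatter is expected. The expected change is a 1.0-fold lower number from compound 2 to compound 3 (0.01 log units; within the scatter). For compound 3 the estimate is 700 nM, with an expected range of 300 nM to 1600 nM.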

Compound 3, half-maximal inhibitory concentration: 4900 nM
Beside the measured number, compound 3's estimate is 7.0-fold (0.85 log units) below it; measured number above the stated range.
By their numbers in this assay, from the lowest: compounds 2 and 1 (each within the scatter of the next); then compound 3.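

In this assay, the amine nitrogen proves sensitive to substitution: ethyl in place of hydrogen gives a 6.8-fold higher number from compound 2 to compound 3 (0.83 log units; beyond the scatter), while the earlier change of amine-bearing group stayed within the scatter at a 1.3-fold lower number from compound 1 to compound 2 (0.11 log units; within the scatter). The 2-(diethylamino)ethyl group also separates from 1-methylpyrrolidin-3-yl, with a 5.3-fold higher number from compound 1 to compound 3 (0.73 log units; beyond the scatter), so compound 3 stands apart from both earlier compounds. No evidence to hand explains this step.

Still open, on these data alone, is whether methyl on the same amine nitrogen would behave like hydrogen or like ethyl. Also open, as far as these compounds go, is how a longer chain such as propyl on that nitrogen would read.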